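A Methylamino Swap Carried Over to a Second Core

The source may report more compounds than this note shows. Statements on the series, on what has been measured and on what is new or still open speak of the compounds shown alone.

Measured compounds:
Compound 1, `COc1ccc(C(=O)c2ccc(OC)c3c2OC(C)(C)C=C3)c(NC(=O)CO)c1`, gives 100 nM in a functional assay on HeLa cells (Homo sapiens) for antiproliferative activity, read by MTT assay, with a stated time of 48 h; on this read-out lower numbers stand for stronger inhibition and higher numbers for weaker inhibition.
Compound 2, `CNCC(=O)Nc1cc(OC)ccc1C(=O)c1ccc(OC)c2c1OC(C)(C)C=C2`, gives 870 nM.
Compound 3, `COc1ccc(C(=O)c2cc(OC)c(OC)c(OC)c2)c(NC(=O)CO)c1`, gives 70 nM.

Compound 1 and compound 2 share a core and differ in one place: methylamino in place of hydroxy on a saturated chain carbon bound to a carbonyl carbon. That change produced an 8.7-fold higher number from compound 1 to compound 2 (0.94 log units; beyond the scatter). Compound 3 stands on a different core; the difference between the two cores is not broken down here. Compound 3 and compound 1 lie within the scatter of each other, while compound 2 sits beyond the scatter above both.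

Compound 4, `CNCC(=O)Nc1cc(OC)ccc1C(=O)c1cc(OC)c(OC)c(OC)c1`, has not been measured. It differs from compound 3 by methylamino in place of hydroxy on a saturated chain carbon bound to a carbonyl carbon, the same change at the same place. Because an 8.7-fold higher number from compound 1 to compound 2 (0.94 log units; beyond the scatter) appeared on the core of compound 1, and compound 3 gives a number close to compound 1, the step is expected to carry over, giving an estimated 8.6-fold higher number from compound 3 to compound 4 (0.93 log units; beyond the scatter). Compound 4 is therefore expected near 600 nM in this assay, with a likely range from 200 nM to 1800 nM.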

Compound 4, half-maximal inhibitory concentration: 690 nM
Beside the measured number, compound 4's estimate is 1.2-fold (0.06 log units) below it; low and high end bracket the measured number.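

In this assay, putting methylamino in place of hydroxy on the second core gave a 9.9-fold higher number from compound 3 to compound 4 (0.99 log units; beyond the scatter), so the loss of inhibition seen on the core of compound 1 appeared here as well. The two steps agree in size: the same change on two cores in this assay, an 8.7-fold higher number (0.94 log units; beyond the scatter) from compound 1 to compound 2 and a 9.9-fold higher number (0.99 log units; beyond the scatter) from compound 3 to compound 4, 1.1-fold (0.05 log units) apart, within the scatter of two such steps

This shows the change carrying over between these two cores in this one assay, but it does not show that it would do so on any other core, and it does not explain why the number rises.

The compounds shown leave open whether other groups at this place, such as a primary amine, dimethylamino or a longer chain, would behave alike on both cores. Going by these compounds, a carboxylic acid there is equally open.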